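The source may report more compounds than this note shows. Statements on the series, on what has been measured and on what is new or still open speak of the compounds shown alone.

Compound 1 `Cc1cc(NCc2ccccn2)n2ncc(-c3ccc(F)cc3)c2n1` in a physicochemical assay for solubility, read by HPLC, using the shake flask method, measured as kinetic solubility, with a stated time of 2 h, at pH 7.4 (on this read-out higher numbers stand for higher solubility and lower numbers for lower solubility), gives < 5000 nM, which is a limit of the assay.
Compound 2 `Cc1cc(NCc2ccccn2)n2ncc(-c3ccc(N(C)C)cc3)c2n1` in this assay gives < 5000 nM, again a limit.
Compound 3 `Cc1cc(NCc2ccccn2)n2ncc(-c3ccccc3C)c2n1` in this assay gives < 5000 nM, also a limit.

Compound 3 therefore stands where every value shown stands, at the limit of < 5000 nM in this assay, at which 3 of the 3 values shown sit, and no number places it more closely. Compound 4 `Cc1cc(NCc2ccccn2)n2ncc(-c3ccco3)c2n1` differs from compound 3 by furan-2-yl in place of 2-methylphenyl on an aromatic carbon. The measured steps that bear on this change, a step that the two limits leave unreadable from compound 1 to compound 3 and a step that the two limits leave unreadable from compound 2 to compound 3, are both hidden between two limits, and a step that the two limits leave unreadable from compound 1 to compound 2 is no clearer, so no size or direction of step can be read from them. Compound 4 is expected to remain near the same limit, the expected step being a step that the limit leaves unreadable from compound 3 to compound 4. For compound 4 the estimate in this assay is 4000 nM, within 1000 nM to 16000 nM.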

Compound 4, solubility: 48800 nM
Compound 4: middle estimate off by 12-fold (1.09 log units), on the low side; measured number above the stated range.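

At this place on the shared core, furan-2-yl in place of 2-methylphenyl gives a step that can be read in this assay: an at least 9.7-fold higher number from compound 3 to compound 4 (0.98 log units; beyond the scatter). Furan-2-yl in place of 4-(dimethylamino)phenyl gives an at least 9.7-fold higher number from compound 2 to compound 4 (0.98 log units; beyond the scatter), and furan-2-yl in place of 4-fluorophenyl gives an at least 9.7-fold higher number from compound 1 to compound 4 (0.98 log units; beyond the scatter). Only compound 4 carries a number rather than a limit, and the other compounds share one: the limit of < 5000 nM in this assay, at which 3 of the 4 values shown sit.

The compounds shown leave open whether the ring oxygen or the five-membered ring goes with this step. As far as these compounds go, whether thiophen-2-yl, with sulfur in place of that oxygen, would stand with compound 4 also remains open.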